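The source may report more compounds than this note shows. Statements on the series, on what has been measured and on what is new or still open speak of the compounds shown alone.

Values measured in a functional assay on HT-29 cells (Homo sapiens) for cytotoxicity, read by neutral red uptake, with a stated time of 72 h; a higher number here means a weaker inhibitor, a lower number a stronger inhibitor:

compound 1 `CCCCCCNc1nc(SCC)nc2ncccc12`: 22500 nM
compound 2 `CCCCNc1nc(SC(C)C)nc2ncccc12`: 32100 nM
compound 3 `CCCCCNc1nc(SC(C)C)nc2ncccc12`: 25200 nM

The three numbers sit close together. Compound 3 gives the second highest of them, and all three fall within the scatter of one another, so no ordering among them can be read from these data.

The next step lengthens the chain on compound 3 by one carbon: methyl in place of hydrogen on a saturated chain carbon, five bonds along the chain from a nitrogen on an aromatic ring, giving compound 4 `CCCCCCNc1nc(SC(C)C)nc2ncccc12`. Within the data shown here, one measured step bears on it directly, the same kind of extension cut one bond nearer the ring: a 1.3-fold lower number from compound 2 to compound 3 (0.11 log units; within the scatter). A second point of reference is compound 1, which carries the same six-carbon chain as compound 4 but a different thioether; in this assay compound 1 gives 22500 nM, again within the scatter of compound 3.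

On that basis the expected step of a 1.3-fold lower number from compound 3 to compound 4 (0.10 log units; within the scatter) is small and not beyond the scatter, if anything a slightly lower number. Compound 4 is therefore estimated at 20000 nM in this assay, with a range from 10000 nM to 45000 nM.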

Compound 4, half-maximal inhibitory concentration: 20200 nM
For compound 4 the middle estimate is 1.0-fold (0.00 log units) below the measured one; the range from low to high includes it.
By their numbers in this assay, from the lowest: compounds 4, 1, 3 and 2 (each within the scatter of the next).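

The added methyl, five bonds along the chain from a nitrogen on an aromatic ring, gives a 1.2-fold lower number from compound 3 to compound 4 (0.10 log units; within the scatter) in this assay, and ethyl in place of hydrogen, four bonds along the chain, gives a 1.6-fold lower number from compound 2 to compound 4 (0.20 log units; within the scatter), so even the longer extension stays within the scatter. On the other side of the core, methyl in place of hydrogen on a saturated chain carbon bound to a saturated chain carbon and a sulfur gives a 1.1-fold lower number from compound 1 to compound 4 (0.05 log units; within the scatter). Read as one change, methyl in place of hydrogen, the step is of like size on two cores: the same change on two cores in this assay, a 1.3-fold lower number (0.11 log units; within the scatter) from compound 2 to compound 3 and a 1.1-fold lower number (0.05 log units; within the scatter) from compound 1 to compound 4, 1.1-fold (0.06 log units) apart, within the scatter of two such steps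

As far as these compounds go, it remains open whether a longer chain on the nitrogen, or an amine or a carboxylic acid at the end of that chain, would move the number beyond the scatter. The same question stands for a phenyl group in place of the alkyl group on the sulfur.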